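The source may report more compounds than this note shows. Statements on the series, on what has been measured and on what is new or still open speak of the compounds shown alone.

Of the compounds shown here, two have been measured in a functional assay on DU-145 cells (Homo sapiens) for cytotoxicity, read by MTT assay, with a stated time of 72 h; on this read-out higher numbers stand for weaker inhibition and lower numbers for stronger inhibition. Compound 1, with the structure `COc1cccc(/C=C/C(=O)Nc2cc(OC)c(OC)c(OC)c2)c1`, gives 3200 nM. Compound 2, with the structure `C#CCOc1cccc(/C=C/C(=O)Nc2cc(C(=O)c3cc(OC)c(OC)c(OC)c3)ccc2OC)c1`, gives 15800 nM in this assay. Of the two numbers, compound 2 stands at the higher one, which on this read-out means the weaker inhibition; the two compounds differ in more than one place, so the gap between their values cannot be traced to a single change. The third compound, compound 3, with the structure `COc1ccc(C(=O)c2cc(OC)c(OC)c(OC)c2)cc1NC(=O)/C=C/c1cccc(OC(F)(F)F)c1`, has not been measured yet. It differs from compound 2 in one place: trifluoromethyl in place of propargyl on an oxygen on an aromatic ring. Among the compounds with values here, no measured pair shows a change of this kind, so no step size can be read from the data. A step from compound 2 to compound 3 of no more than the usual scatter is expected, in either direction, and the expected change is a 1.2-fold lower number from compound 2 to compound 3 (0.08 log units; within the scatter). For compound 3 the expected value in this assay is 13000 nM, with a range from 4500 nM to 40000 nM.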

Compound 3, half-maximal inhibitory concentration: 10200 nM
Estimate against measurement, compound 3: 1.3-fold (0.11 log units) above, and the stated range covers the measured number.
By their numbers in this assay, from the lowest: compound 1; then compounds 3 and 2 (each within the scatter of the next).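

In this assay, within the data shown here, this is the first step that can be read for the group on an oxygen on an aromatic ring, and it is a 1.5-fold lower number from compound 2 to compound 3 (0.19 log units; within the scatter) for trifluoromethyl in place of propargyl. The two groups are quite unlike on paper: propargyl has 3 heavy atoms (3 carbon) and a triple bond, whereas trifluoromethyl has 4 heavy atoms (1 carbon, 3 fluorine) and no triple bond, yet the two compounds lie within the usual scatter of each other, so this read-out does not tell these two groups apart at this place. Nothing measured here offers an explanation for this result.

Going by these compounds, whether other groups on this oxygen would also fall within the scatter remains open, for example an ethyl group, a longer chain, or a chain ending in an amine or a carboxylic acid. Among these compounds, compound 1 differs from both of the other compounds in more than one place, so no step to it can be read, and the separate contributions of those differences remain unknown.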